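Diethylamino to pyrrolidin-1-yl in the amino chalcone series

The source may report more compounds than this note shows. Statements on the series, on what has been measured and on what is new or still open speak of the compounds shown alone.

In a functional assay on HT-29 cells (Homo sapiens) for antiproliferative activity, read by MTT assay, with a stated time of 24 h (on this read-out higher numbers stand for weaker inhibition and lower numbers for stronger inhibition), compound 1 `COc1ccc(C(=O)/C=C/c2ccc(N(C)C)cc2)c2c1C=CC(C)(C)O2` gives 1870 nM. Compound 2 `COc1ccc(C(=O)/C=C/c2ccc(-c3ccccc3)cc2)c2c1C=CC(C)(C)O2` gives > 10000 nM, which is a limit of the assay and not a number. Compound 3 `CCN(CC)c1ccc(/C=C/C(=O)c2ccc(OC)c3c2OC(C)(C)C=C3)cc1` gives 550 nM, the lower of the two actual numbers in the set. Its standing rests on a 3.4-fold lower number from compound 1 to compound 3 (0.53 log units; beyond the scatter), a modest step beyond the scatter, and on an at least 18-fold lower number from compound 2 to compound 3 (1.25 log units; beyond the scatter), a large one.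

The next member is compound 4 `COc1ccc(C(=O)/C=C/c2ccc(N3CCCC3)cc2)c2c1C=CC(C)(C)O2`, with pyrrolidin-1-yl in place of diethylamino on an aromatic carbon, para to a large group: pyrrolidin-1-yl in place of diethylamino on an aromatic carbon. The open diethylamino gives way to a five-membered non-aromatic ring.

Among the measured compounds shown here, no measured step makes this exact exchange. The closest is a 3.4-fold lower number from compound 1 to compound 3 (0.53 log units; beyond the scatter), which also changes only the amino group. Less closely, an at least 5.3-fold higher number from compound 1 to compound 2 (0.72 log units; beyond the scatter) shows that phenyl in place of dimethylamino costs at least modestly in this assay. Compound 4 keeps an amino group at that place, so no loss of that size is expected. A small shift towards compound 1 remains possible, but the expected step is a 1.4-fold higher number from compound 3 to compound 4 (0.13 log units; within the scatter), with nothing beyond the scatter anticipated. For compound 4 the estimated value is 750 nM, with an expected range of 250 nM to 2300 nM.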

Compound 4, half-maximal inhibitory concentration: 8360 nM
The estimate for compound 4 lay 11-fold (1.05 log units) below the measured number; measured number above the stated range.
By their numbers in this assay, from the lowest: compound 3; then compound 1; then compound 4. At a limit, above all of these: compound 2.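

Exchanging one amino group for another at this place, on an aromatic carbon para to a large group, is not a neutral change in this assay: a 15-fold higher number from compound 3 to compound 4 (1.18 log units; beyond the scatter), although diethylamino and pyrrolidin-1-yl carry the same counts of heavy atoms and hydrogen-bond acceptors. The ring also falls behind the open dimethylamino, a 4.5-fold higher number from compound 1 to compound 4 (0.65 log units; beyond the scatter), so an amino group at this place does not by itself keep the number low, which compound 1 and compound 3 alone could not show. The remaining step, an at least 1.1-fold lower number from compound 2 to compound 4 (0.07 log units; that floor lies within the scatter), is taken against a limit and not a number, and its floor does not separate pyrrolidin-1-yl from phenyl: the limit of > 10000 nM in this assay, at which 1 of the 4 values shown sits.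

Going by these compounds, whether the loss belongs to closing the ring as such or to this ring size stays open; piperidin-1-yl or morpholin-4-yl at the same place would bear on that, and dipropylamino would show whether the gain from dimethylamino to diethylamino continues along the open chains. The compounds shown give no reason for the step, and one cell line at one stated time cannot show whether this order holds elsewhere.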